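A few compounds are considered here, and "the series" means these few. Any claim that something is new, unique, unknown or untested is made for them only; others in the source may bear on it.

Measured compounds:
compound 1, `Nc1ccc(-c2cc(=O)c3c(N)c(F)cc(F)c3o2)cc1F` — in a functional assay on MCF7 cells (Homo sapiens) for cytotoxicity, read by neutral red uptake, with a stated time of 3 days (on this read-out lower numbers stand for stronger inhibition and higher numbers for weaker inhibition), compound 1 gives 40 nM;
compound 2, `CCCCCCc1c(F)c(N)c2c(=O)cc(-c3ccc(N)c(F)c3)oc2c1F` — in this assay compound 2 reaches only a limit, > 10000 nM;
compound 3, `CCCOCc1c(F)c(N)c2c(=O)cc(-c3ccc(N)c(F)c3)oc2c1F` — in this assay compound 3 gives 1200 nM.

Compound 3 stands highest of the two numbers; its nearest neighbour is compound 1, separated by a 30-fold higher number from compound 1 to compound 3 (1.48 log units; beyond the scatter). Compound 2 sits at a limit, (the limit of > 10000 nM in this assay, at which 1 of the 3 values shown sits). Compound 4, `CN(C)Cc1c(F)c(N)c2c(=O)cc(-c3ccc(N)c(F)c3)oc2c1F`, differs from compound 3 by dimethylamino in place of propoxy on a saturated chain carbon bound to an aromatic carbon. The step that bears most directly on this change is an at least 8.3-fold lower number from compound 2 to compound 3 (0.92 log units; beyond the scatter), on the same saturated chain carbon, while an at least 250-fold higher number from compound 1 to compound 2 (2.39 log units; beyond the scatter) and a 30-fold higher number from compound 1 to compound 3 (1.48 log units; beyond the scatter) show that any group on that aromatic carbon raised the number. Compound 4 is therefore expected to stay near compound 3, with an estimated step of a 1.5-fold lower number from compound 3 to compound 4 (0.18 log units; within the scatter). For compound 4 the expected value is 800 nM, with a range from 150 nM to 4000 nM.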

Compound 4, half-maximal inhibitory concentration: 72 nM
Compound 4: the middle estimate sits 11-fold (1.05 log units) above what was measured; the measured number lies below the stated range.
By their numbers in this assay, from the lowest: compounds 1 and 4 (each within the scatter of the next); then compound 3. At a limit, above all of these: compound 2.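

In this assay a group on that aromatic carbon need not raise the number: (dimethylamino)methyl in place of hydrogen leaves it within the scatter (a 1.8-fold higher number from compound 1 to compound 4 (0.26 log units; within the scatter)). On the saturated chain carbon, dimethylamino recovers what propoxy (a 17-fold lower number from compound 3 to compound 4 (1.22 log units; beyond the scatter)) and pentyl (an at least 130-fold lower number from compound 2 to compound 4 (2.14 log units; beyond the scatter)) lose. Compound 2 stands at a limit, not at a number: (the limit of > 10000 nM in this assay, at which 1 of the 4 values shown sits).

The compounds shown leave open whether another amine, such as pyrrolidine or morpholine, would do the same on this carbon. They also leave open how a carboxylic acid would fare there.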